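Mirror image of compound 3 in a sodium channel assay

The source may report more compounds than this note shows. Statements on the series, on what has been measured and on what is new or still open speak of the compounds shown alone.

The measured compounds, each with its result in an assay on HEK293 cells for inhibition of sodium channel protein type 3 subunit alpha (Homo sapiens), read by electrophysiology, with a stated time of 3.5 min; a higher number here means a weaker inhibitor, a lower number a stronger inhibitor:
- compound 1, `N#Cc1ccccc1COc1ccc([C@H]2CC[C@@H](C(N)=O)N2)cc1`, reported as a limit: > 63000 nM
- compound 2, `NC(=O)[C@@H]1CC[C@H](c2ccc(Oc3cccc(F)c3)cc2)N1`, gives 100000 nM
- compound 3, `NC(=O)[C@@H]1CCC[C@H](c2ccc(OCc3cccc(F)c3)cc2)N1`, gives 39800 nM

The value for compound 1 is a limit of this assay and not a measured number; among the numbers given, (the limit of > 63000 nM in this assay, at which 1 of the 3 values shown sits). Among the two real numbers, compound 3 stands lowest, so it is the stronger inhibitor of the two, and compound 2 sits at a higher number, a gap that lies beyond the usual scatter.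

Compound 4, `NC(=O)[C@H]1CCC[C@@H](c2ccc(OCc3cccc(F)c3)cc2)N1`, has not yet been measured in this assay. Its relation to compound 3 is purely one of configuration: the two compounds have the same atoms and bonds and differ only in configuration as drawn: 2 of 2 stereo elements differ (all stereocentres are inverted: mirror images); a stereocentre at a saturated ring carbon is drawn S in compound 3 and R in compound 4; a stereocentre at a saturated ring carbon is drawn R in compound 3 and S in compound 4. Nothing is added and nothing removed; the two are mirror images. Within the data shown here, no pair of measured compounds here differs only in configuration, so the data give no direct guide to how large such a step can be in this assay. With every measured number already weak, the expectation is a step of modest size, in no confident direction, plausibly within the scatter: a 1.5-fold higher number from compound 3 to compound 4 (0.18 log units; within the scatter). Compound 4 is therefore estimated at 60000 nM, with a range from 20000 nM to 180000 nM.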

Compound 4, half-maximal inhibitory concentration: 39800 nM
Beside the measured number, compound 4's estimate is 1.5-fold (0.18 log units) above it; the measured number falls inside the stated range.
By their numbers in this assay, from the lowest: compounds 3 and 4 (each within the scatter of the next); then compound 2.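

In this assay, inverting both stereocentres at the saturated ring carbons gives no change at the digits printed from compound 3 to compound 4 (within the scatter). Among these compounds, this pair is the first direct reading of configuration in this set, and nothing else varies within it: the fact that compounds 3 and 4 differ only in the configuration as drawn. At this weak level of inhibition, then, the assay does not separate these two mirror images, so the drawn configuration of compound 3 holds no measurable advantage over that of compound 4, and a result for either one says as much about the other as this pair can show.

The pair inverts both stereocentres together, so it leaves open what inverting only one of them would do, since that would give a compound that is not a mirror image of either. It also cannot say whether configuration would still make no measurable difference in a compound with a much lower number, for example one carrying a carboxylic acid or an amine in place of the amide, where a gap between mirror images might appear.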